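Swapping the Amine on the Shared Core

This account rests on a few compounds, and the source may have more. Where it says the series, first, only, none or still open, it means among the compounds named here.

Of the compounds shown here, two have numbers so far in an assay on HEK293 cells for inhibition of Fatty-acid amide hydrolase 1 (Homo sapiens), read by fluorescence; on this read-out higher numbers stand for weaker inhibition and lower numbers for stronger inhibition. Compound 1 `Cn1ncc2c(-c3ccc4oc(NC5CCCCC5)nc4c3)cccc21` gives 52 nM, the lower of the two; compound 2 `Cn1ccc2cc(-c3ccc4oc(Nc5ccccn5)nc4c3)ccc21` gives 186 nM, and the gap between them lies beyond the usual scatter. Compound 3 `Cn1ncc2c(-c3ccc4oc(N5Cc6ccccc6C5)nc4c3)cccc21` has not been measured. It differs from compound 1 in one place: a group of 9 heavy atoms (8 carbon, 1 nitrogen; one five-membered non-aromatic ring with 1 hetero atom, one six-membered aromatic ring of carbon only) in place of a group of 7 heavy atoms (6 carbon, 1 nitrogen; one six-membered non-aromatic ring of carbon only), on an aromatic carbon. Among the measured compounds shown here, the group that leaves carries one hydrogen-bond donor, the group that enters carries none, and no measured pair differs in a single place, so nothing yet shows what such a swap does in this assay. The expectation is a modest rise in the number, that is, somewhat weaker inhibition, though the change could well stay within the scatter. The step from compound 1 to compound 3 is estimated at a 2.9-fold higher number from compound 1 to compound 3 (0.46 log units; beyond the scatter). For compound 3 the expected value is 150 nM, with a range from 40 nM to 600 nM.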

Compound 3, half-maximal inhibitory concentration: 3.2 nM
Estimate against measurement, compound 3: 47-fold (1.67 log units) above; the whole stated range lies above it.
By their numbers in this assay, from the lowest: compound 3; then compound 1; then compound 2.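

Replacing cyclohexylamino with a group made of a five-membered non-aromatic ring with 1 hetero atom and a six-membered aromatic ring of carbon only gives a 16-fold lower number from compound 1 to compound 3 (1.21 log units; beyond the scatter) in this assay. This aromatic carbon of the shared core, next to the ring nitrogen and the ring oxygen, is therefore a place where the attached group can strongly change the reading. The entering group carries no hydrogen-bond donor and inhibition still strengthens, so a donor here is not required for a low number, although no measured evidence explains the gain.

From the compounds shown here alone, the swap changes the ring system and removes the donor at once, so the part played by each stays open. A plain pyrrolidine attached through its nitrogen, or cyclohexylamino with a methyl group on its nitrogen, would help to separate the two.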